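From bromo to methyl on a shared core

A few compounds are considered here, and "the series" means these few. Any claim that something is new, unique, unknown or untested is made for them only; others in the source may bear on it.

Measured in a physicochemical assay for pharmacokinetics, read by HPLC, in phosphate buffer, at pH 7.4 (on this read-out lower numbers stand for a shorter-lived compound and higher numbers for a longer-lived compound), are two compounds:
- Compound 1 `CCCC(CCC)C(=O)N(C)/N=N/c1ccc(C(N)=O)cc1` gives > 40 h
- Compound 2 `CCCC(CCC)C(=O)N(C)/N=N/c1ccc(Br)cc1` gives 30.4 h

The entry for compound 1 is a limit of the assay and not a number. For the measured compounds named here, compound 2 thus holds the only true number, with 30.4 h as its reading. Compound 3 `CCCC(CCC)C(=O)N(C)/N=N/c1ccc(C)cc1` differs from compound 2 by methyl in place of bromo on an aromatic carbon with methyl in place of bromo on an aromatic carbon. Going by the values given here, the only measured step that bears on this is an at least 1.3-fold lower number from compound 1 to compound 2 (0.11 log units; that floor lies within the scatter) and its floor lies within the scatter, so no step beyond the scatter is expected in this assay here. The expected step is a 1.3-fold lower number from compound 2 to compound 3 (0.10 log units; within the scatter) in the downward direction. Compound 3 is estimated at 24 h with 13 h to 40 h as its expected range.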

Compound 3, half-life: 31.3 h
Beside the measured number, compound 3's estimate is 1.3-fold (0.12 log units) below it; low and high end bracket the measured number.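

In this assay, methyl in place of bromo on an aromatic carbon, para to a large group, gives a 1.0-fold higher number from compound 2 to compound 3 (0.01 log units; within the scatter), so this position does not tell the two groups apart. Methyl in place of carbamoyl gives an at least 1.2-fold lower number from compound 1 to compound 3 (0.10 log units; that floor lies within the scatter), which fixes only a floor for that change. From the compounds shown here alone, its true size stays unknown because compound 1 stands at a limit and not at a number: the limit of > 40 h in this assay, at which 1 of the 3 values shown sits. The compounds shown leave open whether an amine, a carboxylic acid or a longer chain at this position would shift the half-life beyond the scatter.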